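Benzimidazole acetic acids: from a ketone to an amide

The source may report more compounds than this note shows. Statements on the series, on what has been measured and on what is new or still open speak of the compounds shown alone.

Of the compounds shown here, two have been measured in an assay on HEK293 cells for displacement of a labelled ligand from prostaglandin D2 receptor 2 (Homo sapiens); a higher number here means a weaker inhibitor, a lower number a stronger inhibitor. Compound 1 `Cc1ccccc1CSc1nc2ccccc2n1CC(=O)O` gives 810 nM in this assay. Compound 2 `COc1ccc(C(=O)c2ccccc2)cc1CSc1nc2cc(F)ccc2n1CC(=O)O`, which carries a methoxy-substituted benzoyl arm and a fluorine on the shared core, gives 1.7 nM, the lowest of the two numbers, and its gap to compound 1 lies well beyond the scatter.

Compound 3 `CCN(Cc1ccccc1)C(=O)c1ccc(OC)c(CSc2nc3cc(F)ccc3n2CC(=O)O)c1` keeps everything of compound 2 except one change: benzyl(ethyl)amino in place of phenyl on a carbonyl carbon. Within the data shown here, no measured pair in the set isolates this change, so its effect can only be guessed. Because compound 2 already stands at 1.7 nM, compound 3 is expected to remain a strong binder, with a step from compound 2 to compound 3 of a 2.9-fold higher number from compound 2 to compound 3 (0.47 log units; beyond the scatter) that may be small or a modest loss. The estimate for compound 3 in this assay is 5 nM, within a range from 1 nM to 30 nM.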

Compound 3, half-maximal inhibitory concentration: 495 nM
Compound 3: the middle estimate sits 99-fold (2.00 log units) below what was measured; measured number outside the range, above it.
By their numbers in this assay, from the lowest: compound 2; then compounds 3 and 1 (each within the scatter of the next).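

Turning benzoyl into benzyl(ethyl)carbamoyl gives a 290-fold higher number from compound 2 to compound 3 (2.46 log units; beyond the scatter) in this assay. The low number of compound 2 therefore does not carry over to every group at this place, and this position proves sensitive to the change. Both groups hold one six-membered aromatic ring of carbon only, so the presence of such a ring does not by itself preserve the low number, and nothing available here accounts for the loss.

The compounds shown leave open whether a small amide on the same carbonyl carbon, such as dimethylamino or a plain amino group, would behave like compound 2 or like compound 3. Also open, from the compounds shown here alone, is how a direct replacement of ethyl by methyl, or of benzyl by phenyl, on the amide nitrogen would read.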